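The source may report more compounds than this note shows. Statements on the series, on what has been measured and on what is new or still open speak of the compounds shown alone.

Values in a functional assay on MCF7 cells (Homo sapiens) for inhibition, read by CCK-8 assay, with a stated time of 48 h; a lower number here means a stronger inhibitor of growth, a higher number a weaker inhibitor of growth:
compound 1 `CN1CCN(c2ccc(Nc3ncc(Cl)c(NCc4ccccc4)n3)nc2)CC1`: 17300 nM
compound 2 `Cc1ccc(CNc2nc(Nc3ccc(N4CCN(C)CC4)cn3)ncc2Cl)cc1`: 38100 nM
compound 3 `CCc1ccc(Nc2nc(Nc3ccc(N4CCN(C)CC4)cn3)ncc2Cl)cc1`: 8230 nM

Compound 3 holds the lowest of the three numbers. Compound 4 `CN1CCN(c2ccc(Nc3ncc(Cl)c(Nc4ccc(C(C)(C)C)cc4)n3)nc2)CC1` carries tert-butyl in place of ethyl on an aromatic carbon, para to a large group: tert-butyl in place of ethyl on an aromatic carbon. Going by the values given here, no measured step makes this exact change. The closest is a 2.2-fold higher number from compound 1 to compound 2 (0.34 log units; beyond the scatter), with methyl in place of hydrogen on an aromatic carbon. The steps of a 2.1-fold lower number from compound 1 to compound 3 (0.32 log units; beyond the scatter) and a 4.6-fold lower number from compound 2 to compound 3 (0.67 log units; beyond the scatter) exchange the whole group on nitrogen, so they bear on it only loosely. On the first of these steps, a small rise in this assay is expected, possibly none beyond the scatter. The expected size is a 1.3-fold higher number from compound 3 to compound 4 (0.13 log units; within the scatter). Compound 4 is estimated at 11000 nM, with an expected range of 4500 nM to 28000 nM.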

Compound 4, concentration for 50% growth inhibition: 12600 nM
Beside the measured number, compound 4's estimate is 1.1-fold (0.06 log units) below it, within the range that was stated.
By their numbers in this assay, from the lowest: compounds 3, 4 and 1 (each within the scatter of the next, the first and the last beyond it); then compound 2.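

In this assay, tert-butyl in place of ethyl on an aromatic carbon gives a 1.5-fold higher number from compound 3 to compound 4 (0.18 log units; within the scatter) and so does not separate the two groups at this place. Against the benzyl compound the exchange gives a 1.4-fold lower number from compound 1 to compound 4 (0.14 log units; within the scatter) as well, whereas against the 4-methylbenzyl compound it gives a 3.0-fold lower number from compound 2 to compound 4 (0.48 log units; beyond the scatter) and only that pair stands apart. Nothing at hand accounts for these numbers.

Open remains how a carboxylic acid, an amine or a longer chain in place of tert-butyl on this aromatic carbon would read in this assay here.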